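A few compounds are considered here, and "the series" means these few. Any claim that something is new, unique, unknown or untested is made for them only; others in the source may bear on it.

Measured in a functional assay on HepG2 cells (Homo sapiens) for cytotoxicity, read by MTT assay; on this read-out higher numbers stand for weaker inhibition and lower numbers for stronger inhibition:
- Compound 1 `C#CCOc1cc(/C=C/C(=O)c2ccc(OC)c3c2OC(C)(C)C=C3)ccc1OC`: > 10000 nM, a limit
- Compound 2 `COc1ccc(/C=C/C(=O)c2ccc(OC)c3c2OC(C)(C)C=C3)cc1OCCO`: > 10000 nM, a limit
- Compound 3 `COc1ccc(/C=C/C(=O)c2ccc(OC)c3c2OC(C)(C)C=C3)cc1OC(=O)C(C)C`: 250 nM

Among these three, only compound 3 has a true number, 250 nM, and it is the most potent of the group on the steps that can be read. Compound 4 `COc1ccc(/C=C/C(=O)c2ccc(OC)c3c2OC(C)(C)C=C3)cc1OC(=O)CCl` differs from it at a single place: chloromethyl in place of isopropyl on a carbonyl carbon. In words, chloromethyl stands in place of isopropyl on a carbonyl carbon.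

Among the compounds with values here, two measured steps bear on this site, though only indirectly. Both are large: an at least 40-fold lower number from compound 1 to compound 3 (1.60 log units; beyond the scatter) and an at least 40-fold lower number from compound 2 to compound 3 (1.60 log units; beyond the scatter). Each puts isopropylcarbonyl in place of another group on an oxygen on an aromatic ring. The third step, a step that the two limits leave unreadable from compound 1 to compound 2, cannot be read. Compound 4 keeps a carbonyl on that oxygen, so it retains the feature that separates compound 3 in those two large steps. Within the data shown here, no measured step changes the group on the carbonyl carbon itself, which leaves the direction open, and no step beyond the scatter is expected.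

The expected change is a 1.2-fold higher number from compound 3 to compound 4 (0.08 log units; within the scatter). Compound 4 is estimated at 300 nM, with an expected range from 80 nM to 1500 nM.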

Compound 4, half-maximal inhibitory concentration: 120 nM
Compound 4: middle estimate off by 2.5-fold (0.40 log units), on the high side; the range from low to high includes it.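

In this assay, the group on the carbonyl carbon now turns out to count in its own right: chloromethyl in place of isopropyl gives a 2.1-fold lower number from compound 3 to compound 4 (0.32 log units; beyond the scatter), a modest step and the only one that can be read at this position. The carbonyl on the oxygen on the aromatic ring also keeps its large advantage with a second group on its carbonyl carbon, as shown by an at least 83-fold lower number from compound 2 to compound 4 (1.92 log units; beyond the scatter) and by an at least 83-fold lower number from compound 1 to compound 4 (1.92 log units; beyond the scatter), so the large steps seen earlier are not tied to isopropyl alone. These two large steps rest on limits rather than numbers, so their sizes are minimum sizes: the limit of > 10000 nM in this assay, at which 2 of the 4 values shown sit.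

With this single pair at the position, the compounds shown cannot separate the effect of the chlorine from that of losing the isopropyl group itself. As far as these compounds go, a plain methyl, a bromomethyl, a longer chain or an amine on the carbonyl carbon would be needed to tell whether the number keeps falling, and how far the position tolerates change remains open.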